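The source may report more compounds than this note shows. Statements on the series, on what has been measured and on what is new or still open speak of the compounds shown alone.

Measured in a functional assay on K562 cells (Homo sapiens) for inhibition, read by CCK-8 assay, with a stated time of 72 h; a higher number here means a weaker inhibitor, a lower number a stronger inhibitor:
- compound 1 `O=C(/C=C/c1cccnc1)NCCCCCCc1cccc(S(=O)(=O)Nc2ccc(Cl)cc2)c1`: 6.41 nM
- compound 2 `O=C(/C=C/c1cccnc1)NCCCCCCc1cccc(S(=O)(=O)Nc2ccc(C(F)(F)F)cc2)c1`: 44.9 nM

In this assay, compound 2 stands at 44.9 nM, the higher of the two numbers and so the weaker inhibitor of the pair. The next compound, compound 3 `O=C(/C=C/c1cccnc1)NCCCCCCc1cccc(S(=O)(=O)Nc2ccc(Oc3ccccc3)cc2)c1`, has not yet been measured. It differs from compound 2 by phenoxy in place of trifluoromethyl on an aromatic carbon, para to a large group.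

Among the compounds with values here, only one measured step bears on this change: a 7.0-fold higher number from compound 1 to compound 2 (0.85 log units; beyond the scatter), with trifluoromethyl in place of chloro on an aromatic carbon. This modest step lies beyond the scatter and shows that a change at this place can move the number. Within the data shown here, no measured compound carries phenoxy, however, so the data give no direction for the new group. A step of that modest size is therefore possible either way, but no step beyond the scatter is the central expectation. The estimate means a 1.1-fold lower number from compound 2 to compound 3 (0.05 log units; within the scatter), an expected step that remains uncertain. For compound 3 the estimated value is 40 nM, with an expected range from 7 nM to 280 nM.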

Compound 3, half-maximal inhibitory concentration: 5.12 nM
The estimate for compound 3 lay 7.8-fold (0.89 log units) above the measured number, and the stated range ends above it.
By their numbers in this assay, from the lowest: compounds 3 and 1 (each within the scatter of the next); then compound 2.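

In this assay, phenoxy on this aromatic carbon gives an 8.8-fold lower number from compound 2 to compound 3 (0.94 log units; beyond the scatter) and so recovers what trifluoromethyl had lost, which shows that the position accepts a whole six-membered aromatic ring of carbon, joined through oxygen, with no penalty in the number. Against chloro, the same group gives a 1.3-fold lower number from compound 1 to compound 3 (0.10 log units; within the scatter), a step within the scatter, so chloro and phenoxy cannot be told apart here, and among these three compounds trifluoromethyl alone stands apart, its steps to both others lying beyond the scatter. Nothing given here accounts for why trifluoromethyl differs from the other two groups.

The compounds shown leave open whether the oxygen or the ring of phenoxy matters more, a question that methoxy and a directly attached phenyl group would help to separate. Going by these compounds, how an amine or a carboxylic acid on this carbon would read in this assay also remains open, as does whether the chloro and phenoxy results would hold with a longer chain.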